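This account rests on a few compounds, and the source may have more. Where it says the series, first, only, none or still open, it means among the compounds named here.

Measured compounds:
compound 1, `Cc1ccc([C@H](C)NC(=O)Cn2nnc3ccccc3c2=O)cc1`, 12000 nM
compound 2, `C[C@@H](NC(=O)Cn1nnc2ccccc2c1=O)c1ccccc1`, 1200 nM
compound 3, `C[C@H](NC(=O)Cn1nnc2ccccc2c1=O)c1ccc(Br)cc1`, 900 nM

In a physicochemical assay for solubility, read by HPLC, in phosphate buffer, with a stated time of 16 h, at pH 6.8 (on this read-out higher numbers stand for higher solubility and lower numbers for lower solubility), compound 1 gives the highest of the three numbers. Compound 2 gives a lower number than compound 1, and compound 3 gives the lowest number of the three. For the measured compounds named here, the one step that is measured in one place is a 13-fold lower number from compound 1 to compound 3 (1.12 log units; beyond the scatter), a large drop that comes with bromo in place of methyl on an aromatic carbon.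

Compound 4, `Cc1ccc([C@H](C)NC(=O)Cn2nnc3ccccc3c2=O)nc1`, is not yet measured. It differs from compound 1 in one place: 5-methylpyridin-2-yl in place of 4-methylphenyl on a saturated chain carbon bound to an amide-type nitrogen and a saturated chain carbon

Going by the values given here, no measured step matches this change. The step from compound 1 to compound 3 swaps one group for another on the ring, whereas the change to compound 4 exchanges the ring itself for one with a hetero atom and one hydrogen-bond acceptor. The measured step therefore gives no direct guide, and the account must treat compound 4 with caution. Compound 4 is expected to give a number near that of compound 1 or somewhat higher, with the step estimated as a 1.7-fold higher number from compound 1 to compound 4 (0.22 log units; within the scatter). The estimate for compound 4 in this assay is 20000 nM, with a range from 7000 nM to 60000 nM.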

Compound 4, solubility: 2000 nM
Compound 4: middle estimate off by 10-fold (1.00 log units), on the high side, outside the stated range (below it).
By their numbers in this assay, from the lowest: compounds 3, 2 and 4 (each within the scatter of the next, the first and the last beyond it); then compound 1.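

In this assay, the group on the saturated chain carbon bound to an amide-type nitrogen and a saturated chain carbon now has a second measured exchange, and this one replaces the ring itself rather than only the group on it: 5-methylpyridin-2-yl in place of 4-methylphenyl gives a 6.0-fold lower number from compound 1 to compound 4 (0.78 log units; beyond the scatter). Both exchanges away from 4-methylphenyl among these compounds lower the number, so compound 1 stays alone at the top, while the other measured exchange at this place, 5-methylpyridin-2-yl in place of 4-bromophenyl, gives a 2.2-fold higher number from compound 3 to compound 4 (0.35 log units; beyond the scatter) and shows that the two replacements can be told apart. Nothing measured alongside these numbers accounts for either step.

The compounds shown leave open whether an amine or a carboxylic acid on this ring would bring the number back to that of compound 1 or leave it lower, and whether a pyrimidinyl ring would follow 5-methylpyridin-2-yl. They also leave open whether the same order of compound 1, compound 3 and compound 4 would hold for a longer chain in place of the methyl group on the saturated chain carbon.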